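Pyrrolidin-1-yl amide expected close to compound 1

This account rests on a few compounds, and the source may have more. Where it says the series, first, only, none or still open, it means among the compounds named here.

In a functional assay on IMR-32 cells (Homo sapiens) for antiproliferative activity, read by sulforhodamine B assay, with a stated time of 48 h (on this read-out higher numbers stand for weaker inhibition and lower numbers for stronger inhibition), compound 1 (`COc1ccc(C[C@@H](O)/C=C/C=C/C(=O)NCc2ccc(Cl)cc2)cc1OC`) gives 15700 nM and stands within the scatter of both other measured compounds. Compound 3 (`COc1ccc(C[C@@H](O)/C=C/C=C/C(=O)NCc2cc(OC)c(OC)c(OC)c2)cc1OC`) gives 13400 nM on the same read-out. Compound 2 (`COc1ccc(C[C@@H](O)/C=C/C=C/C(=O)N2CCN(C)CC2)cc1OC`) gives 18900 nM on that read-out too. Compound 4 (`COc1ccc(C[C@@H](O)/C=C/C=C/C(=O)N2CCCC2)cc1OC`) has pyrrolidin-1-yl in place of (4-chlorobenzyl)amino on a carbonyl carbon. For the measured compounds named here, the one measured step bearing on this replaces the same group with 4-methylpiperazin-1-yl and comes to a 1.2-fold higher number from compound 1 to compound 2 (0.08 log units; within the scatter) on the shared core. No step beyond the scatter is therefore expected in this assay here. The estimated step is a 1.1-fold higher number from compound 1 to compound 4 (0.03 log units; within the scatter) and nothing larger is anticipated. Compound 4 is expected at 17000 nM (estimated range 9000 nM to 30000 nM).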

Compound 4, half-maximal inhibitory concentration: 12000 nM
For compound 4 the middle estimate is 1.4-fold (0.15 log units) above the measured one; the measured number falls inside the stated range.
By their numbers in this assay, from the lowest: compounds 4, 3, 1 and 2 (each within the scatter of the next).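

In this assay, pyrrolidin-1-yl on the carbonyl carbon gives a 1.3-fold lower number from compound 1 to compound 4 (0.12 log units; within the scatter) and a 1.6-fold lower number from compound 2 to compound 4 (0.20 log units; within the scatter), both within the scatter. The flat picture at this position therefore extends to a group with fewer heavy atoms than (4-chlorobenzyl)amino, with no aromatic ring and no amide hydrogen. No measured data on the compounds explain this result.
As far as these compounds go, whether a free carboxylic acid or a dimethylamino group at this carbonyl carbon would stay within the scatter remains open. The compounds shown also leave open how changes elsewhere on the shared core would read out.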